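The compounds below may be only part of what the source reports. "The series", "measured", "known", "first", "only" and "open" are said of these compounds alone.

Three aryltriazenes built on one shared core have been tested in a functional assay on L1210 cells (Mus musculus) for antiproliferative activity; a lower number here means a less potent compound, a higher number a more potent compound, by a factor of ten per unit of this negative logarithm. Compound 1 `Cc1ccc(/N=N/N(C)C)cc1` gives 3.76, compound 2 `COC(=O)c1ccc(/N=N/N(C)C)cc1` gives 3.2, and compound 3 `COC(=O)c1cccc(/N=N/N(C)C)c1` gives 3.42. Compounds 2 and 3 contain the same atoms joined differently, and the difference between their two cores is not broken down here. Among the compounds with values here, the one counted step among the measured compounds is methyl in place of methoxycarbonyl on an aromatic carbon, which gave a number 0.56 log units higher from compound 2 to compound 1 (beyond the scatter).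

Compound 4 `Cc1cccc(/N=N/N(C)C)c1` has not yet been measured in this assay. It differs from compound 3 by methyl in place of methoxycarbonyl on an aromatic carbon. This is the same kind of change as that from compound 2 to compound 1, but not the same one: in compound 4 the methyl sits meta to a group of 5 heavy atoms, whereas in compound 1 it sits para to a group of 5 heavy atoms. Resting on a number 0.56 log units higher from compound 2 to compound 1 (beyond the scatter), which lay beyond the scatter, the step for compound 4 is expected to be a number 0.48 log units higher from compound 3 to compound 4 (beyond the scatter). What the changed place adds is not known from these compounds. Compound 4 in this assay is therefore estimated at 3.9, expected between 3.5 and 4.3.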

Compound 4, logarithm of the reciprocal of the active concentration, log(1/C): 3.4
Compound 4: the middle estimate sits 0.50 log units above what was measured; measured number outside the range, below it.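

In this assay, methyl in place of methoxycarbonyl on an aromatic carbon, meta to a group of 5 heavy atoms, gave a number 0.02 log units lower from compound 3 to compound 4 (within the scatter). The change therefore does not carry over as a fixed increment between these two cores: the same change on two cores in this assay, a number 0.56 log units higher (beyond the scatter) from compound 2 to compound 1 and a number 0.02 log units lower (within the scatter) from compound 3 to compound 4, 0.58 log units apart, beyond the scatter of two such steps. Within the data shown here, this shows that, for this one pair of cores, the size of the step depends on the core that carries it, so a step read on one core is a poor guide to the other; with only two steps, it does not show what in the changed place sets the gap, nor how the change would behave on any further core.

The compounds shown leave open whether another group in place of methoxycarbonyl, such as an amine, a carboxylic acid or a longer chain, would also give steps that differ between the two cores. They also leave open which of the two steps, if either, a third core would resemble.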